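Notes on the step from compound 3 to compound 4

This account rests on a few compounds, and the source may have more. Where it says the series, first, only, none or still open, it means among the compounds named here.

Measured in a functional assay on BaF3 cells (Mus musculus) for inhibition, read by CCK-8 assay, with a stated time of 72 h; on this read-out lower numbers stand for stronger inhibition of growth and higher numbers for weaker inhibition of growth:
- Compound 1 `Cc1ccc(NC(=O)Nc2ccc(Oc3cc(N)ncn3)cc2)cc1C(F)(F)F`: > 10000 nM, a limit of the assay and not a number
- Compound 2 `Cc1ccc(NC(=O)Nc2ccc(Oc3cc(N4CCNC[C@H]4C)ncn3)cc2)cc1C(F)(F)F`: 9670 nM
- Compound 3 `COCCNc1cc(Oc2ccc(NC(=O)Nc3ccc(C)c(C(F)(F)F)c3)cc2)ncn1`: 7950 nM

Among the measured compounds shown here, only two exact values exist, and the gap between them is a 1.2-fold lower number from compound 2 to compound 3 (0.09 log units; within the scatter). Compound 3 therefore cannot be ranked on the numbers. Compound 1 stands at the limit of > 10000 nM in this assay, at which 1 of the 3 values shown sits.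

Compound 4 `Cc1ccc(NC(=O)Nc2ccc(Oc3cc(NCCN)ncn3)cc2)cc1C(F)(F)F` has amino in place of methoxy on a saturated chain carbon, two bonds along the chain from a nitrogen on an aromatic ring. The side chain thus reads (2-aminoethyl)amino instead of (2-methoxyethyl)amino.

Besides the gap above, the measured steps that bear on this change are an at least 1.0-fold lower number from compound 1 to compound 2 (0.01 log units; that floor lies within the scatter) and an at least 1.2-fold lower number from compound 1 to compound 3 (0.09 log units; that floor lies within the scatter). Both rest on the limit and give only floors. None of the three shows a change beyond the scatter, so no step beyond the scatter is expected in this assay. The estimate is a 1.1-fold lower number from compound 3 to compound 4 (0.06 log units; within the scatter), and this expected step carries wide uncertainty. For compound 4 the expected value is 7000 nM, with an estimated range of 2500 nM to 10000 nM.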

Compound 4, concentration for 50% growth inhibition: > 10000 nM
Compound 4 ended at the assay's limit; the forecaster's own chance of this, stated with the estimate: 35%; at least 1.4-fold (0.15 log units) between middle value and limit.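

In this assay compound 4 gives > 10000 nM, which is a limit of the assay and not a number. Amino in place of methoxy on the saturated chain carbon gives an at least 1.2-fold higher number from compound 3 to compound 4 (0.09 log units; that floor lies within the scatter), and (2-aminoethyl)amino in place of 2-methylpiperazin-1-yl on the aromatic carbon gives an at least 1.0-fold higher number from compound 2 to compound 4 (0.01 log units; that floor lies within the scatter); both are floors within the scatter, so neither change is shown to move the number, and neither is shown to leave it unchanged. The step from compound 1 to compound 4 cannot be read, and the limit is now shared: the limit of > 10000 nM in this assay, at which 2 of the 4 values shown sit.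

Still open, on these data alone, is whether any side chain here moves the number beyond the scatter, for instance hydroxy in place of methoxy on the same chain carbon, or a longer chain ending in methoxy. As far as these compounds go, how far compound 4 lies past its limit also stays open.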